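From 4-methylphenyl to 4-chlorophenyl

The source may report more compounds than this note shows. Statements on the series, on what has been measured and on what is new or still open speak of the compounds shown alone.

Compound 1 `CC1(C)[C@H]2CC[C@]1(C)N(Cc1cn(-c3ccccc3)nn1)C(=O)C2`: 50 nM
Compound 2 `Cc1ccc(-n2cc(CN3C(=O)C[C@@H]4CC[C@@]3(C)C4(C)C)nn2)cc1`: 50 nM

Among the compounds with values here, in a functional assay on LoVo cells (Homo sapiens) for inhibition, read by MTT assay, with a stated time of 24 h (a lower number here means a stronger inhibitor, a higher number a weaker inhibitor), compound 2 gives 50 nM and stands level with its only measured neighbour, compound 1, which gives 50 nM. The next compound, compound 3 `CC1(C)[C@H]2CC[C@]1(C)N(Cc1cn(-c3ccc(Cl)cc3)nn1)C(=O)C2`, keeps the shared core and alters a single place: chloro in place of methyl on an aromatic carbon. This is chloro in place of methyl on an aromatic carbon, para to a large group, so that 4-methylphenyl becomes 4-chlorophenyl.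

Within the data shown here, one measured step bears on this change. It is no change at the digits printed from compound 1 to compound 2 (within the scatter), with methyl in place of hydrogen on the same aromatic carbon. That step stays within the scatter, so the two measured compounds show no sensitivity to what sits there. Among the measured compounds shown here, a single step is thin evidence, however, and no chloro compound has yet been measured. In this assay no shift beyond the scatter is therefore expected, in either direction. The expected step is no change at the digits printed from compound 2 to compound 3 (within the scatter). For compound 3 the estimated value is 50 nM, with an expected range from 20 nM to 125 nM.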

Compound 3, half-maximal inhibitory concentration: 160 nM
Compound 3: middle estimate off by 3.2-fold (0.51 log units), on the low side; the whole stated range lies below it.
By their numbers in this assay, from the lowest: compounds 1 and 2 (each within the scatter of the next); then compound 3.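

In this assay, the aromatic carbon para to a large group no longer looks indifferent to what it carries: replacing methyl with chloro there gives a 3.2-fold higher number from compound 2 to compound 3 (0.51 log units; beyond the scatter), a modest loss of inhibition that lies beyond the scatter. Measured against hydrogen at the same place, the chloro group gives a 3.2-fold higher number from compound 1 to compound 3 (0.51 log units; beyond the scatter), so compound 3 stands apart from both compound 1 and compound 2, while those two remain level with each other; the position therefore tolerates methyl as well as hydrogen but does not accept every single-atom replacement equally. Nothing among the available data accounts for the difference between chloro and methyl at this place.

The three compounds cannot show whether the loss belongs to chloro alone or would recur with other groups on this carbon, such as fluoro, bromo, methoxy, an amine or a carboxylic acid. They also leave open whether a chloro group placed elsewhere on the six-membered aromatic ring, or a longer chain on this same carbon, would give a similar number.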